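A few compounds are considered here, and "the series" means these few. Any claim that something is new, unique, unknown or untested is made for them only; others in the source may bear on it.

Measured so far:
- compound 1 `COc1ccc(NC(=O)C2Cc3cc(OC)c(OC)cc3C2=O)cc1`: 2.08
- compound 2 `COc1cc2c(cc1OC)C(=O)C(C(=O)Nc1cccc(Cl)c1)C2`: 2.76

In a physicochemical assay for lipophilicity, read by mass spectrometry (a lower number here means a more polar compound, a higher number a more lipophilic compound), compound 2 has the higher of the two numbers, at 2.76. Compound 3 `COc1cc2c(cc1OC)C(=O)C(C(=O)Nc1cccc(Br)c1)C2` carries bromo in place of chloro on an aromatic carbon of compound 2 (bromo in place of chloro on an aromatic carbon). Among the measured compounds shown here, only one measured step bears on this change, and only indirectly: a number 0.68 log units higher from compound 1 to compound 2 (beyond the scatter). For the measured compounds named here, that step exchanges 4-methoxyphenyl for 3-chlorophenyl, so it replaces a whole group, and no measured pair isolates chloro against bromo. A much smaller exchange is therefore expected here than in that step, with any movement in this assay expected to be upward and to stay within the scatter. The expected change is a number 0.12 log units higher from compound 2 to compound 3 (within the scatter). For compound 3 the estimated value is 2.88, with an expected range of 2.6 to 3.15.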

Compound 3, partition coefficient: 3.03
The estimate for compound 3 lay 0.15 log units below the measured number; the range from low to high includes it.
By their numbers in this assay, from the lowest: compound 1; then compounds 2 and 3 (each within the scatter of the next).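

In this assay, bromo in place of chloro on an aromatic carbon, meta to a large group, gives a number 0.27 log units higher from compound 2 to compound 3 (within the scatter) and leaves compounds 2 and 3 unseparated at this position. The separation from compound 1 remains with either halogen: 3-bromophenyl in place of 4-methoxyphenyl gives a number 0.95 log units higher from compound 1 to compound 3 (beyond the scatter) and also lies beyond the scatter, as does a number 0.68 log units higher from compound 1 to compound 2 (beyond the scatter) in the chlorinated pair. No supporting evidence is available to explain these steps.

Both steps from compound 1 exchange a whole aryl group. The measured compounds do not separate the arrival of the halogen from the loss of 4-methoxyphenyl. Also open, going by these compounds, is how a nitrile, a primary amine or a carboxylic acid on the same aromatic carbon would read in this assay against the two halogens.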